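Five-membered ring swap from compound 3 to compound 4

This account rests on a few compounds, and the source may have more. Where it says the series, first, only, none or still open, it means among the compounds named here.

For the measured compounds named here, compound 3 `c1c[nH]c(-c2ccccc2OCC2=NCCN2)c1` gives 1.26 nM in a functional assay for activation of Alpha-1A adrenergic receptor (Homo sapiens), read by calcium flux (on this read-out lower numbers stand for an effect already at smaller amounts and higher numbers for an effect only at larger amounts of compound), and is the only defined number in the set. Compound 1 `Cc1cccnc1-c1ccccc1OCC1=NCCN1` gives only a limit, < 100000 nM. Compound 2 `Cc1ccnc(-c2ccccc2OCC2=NCCN2)c1` likewise gives only a limit, < 100000 nM. Going by the values given here, both of these sit at the limit of < 100000 nM in this assay, at which 2 of the 3 values shown sit, so no step between measured compounds can be sized, and compound 3 stands alone as the single value on the scale. Compound 4 `Cc1ccc(-c2ccccc2OCC2=NCCN2)s1` differs from compound 3 by 5-methylthiophen-2-yl in place of 1H-pyrrol-2-yl on an aromatic carbon. Among the compounds with values here, with no measured step to lean on, the expected step of a 40-fold higher number from compound 3 to compound 4 (1.60 log units; beyond the scatter) is taken to run toward weaker activation, beyond the scatter. Compound 4 is accordingly estimated at 50 nM in this assay, with a range from 5 nM to 500 nM.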

Compound 4, half-maximal effective concentration: 25.1 nM
Compound 4: the middle estimate sits 2.0-fold (0.30 log units) above what was measured; measured number inside the range.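

At this position, on an aromatic carbon ortho to a group of 7 heavy atoms, the series now has a measured step: a 20-fold higher number from compound 3 to compound 4 (1.30 log units; beyond the scatter). A defined number therefore survives loss of the hydrogen-bond donor of 1H-pyrrol-2-yl, at a large cost in this assay. Compound 1 and compound 2 remain limits, so steps involving them cannot be read: the limit of < 100000 nM in this assay, at which 2 of the 4 values shown sit.

The change swaps the hetero atom and adds a methyl at once, so the two contributions stay unseparated. Unsubstituted thiophen-2-yl, or a 5-methyl-1H-pyrrol-2-yl group, would separate them, and an amine on the five-membered ring remains open.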